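The source may report more compounds than this note shows. Statements on the series, on what has been measured and on what is new or still open speak of the compounds shown alone.

Compound 1 `CSCC[C@H](NC(=O)c1ccc(NCc2cncn2Cc2ccccc2C#N)cc1-c1ccccc1)C(=O)O`: > 10 uM
Compound 2 `CSCC[C@H](NC(=O)c1ccc(CNCc2[nH]cnc2C)cc1-c1ccccc1C)C(=O)O`: > 10 uM

Both compounds were tested in a functional assay on NIH3T3 cells (Mus musculus); on this read-out higher numbers stand for an effect only at larger amounts of compound and lower numbers for an effect already at smaller amounts. In this test, compound 1 gives > 10 uM, which is a limit of the assay and not a number. Compound 2 gives > 10 uM, which is also a limit. For the measured compounds named here, compound 1 therefore stands with the only other measured compound at the limit of > 10 uM in this assay, at which 2 of the 2 values shown sit, and its exact position is unknown.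

Compound 3 `CSCC[C@H](NC(=O)c1ccc(NCc2cncn2Cc2cccc(Cl)c2)cc1-c1ccccc1)C(=O)O` keeps the core of compound 1 and alters one group: 3-chlorophenyl in place of 2-cyanophenyl on a saturated chain carbon bound to an aromatic nitrogen. In words, 3-chlorophenyl takes the place of 2-cyanophenyl on a saturated chain carbon bound to an aromatic nitrogen, so 2-cyanobenzyl becomes 3-chlorobenzyl.

Going by the values given here, no two measured compounds differ in just one place, so the data do not show directly what a change of this kind does. The expected step, a step that the limit leaves unreadable from compound 1 to compound 3, is none beyond the scatter, with neither direction favoured. With both measured compounds at the limit of > 10 uM in this assay, at which 2 of the 2 values shown sit, a limit is also the most likely report for the new compound. The estimate for compound 3 is 15 uM, with an expected range from 5 uM to 40 uM.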

Compound 3, concentration for half-maximal effect: > 10 uM
Compound 3: no number, only a limit; the forecaster's own chance of this, stated with the estimate: 75%; the middle value lies beyond the limit too.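

In this assay compound 3 gives > 10 uM, which is a limit of the assay and not a number. Compound 1 also stands at a limit, so no step can be read between compound 1 and compound 3: the limit of > 10 uM in this assay, at which 3 of the 3 values shown sit. As far as these compounds go, whether replacing 2-cyanobenzyl with 3-chlorobenzyl changes the effect at all, and how far each compound lies beyond the limit, stays open.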